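The source may hold more compounds than are shown below. What is called first, only, known or untested is meant among the compounds shown, and "the series" means these compounds.

Among the compounds measured so far, compound 3 `COc1ccc(NC(=O)Nc2cccc(CNc3ncnc4ccccc34)c2)cc1` carries the lowest number: in a functional assay on MGC-803 cells (Homo sapiens) for antiproliferative activity, read by MTT assay (on this read-out lower numbers stand for stronger inhibition and higher numbers for weaker inhibition), compound 3 gives 27300 nM. Its nearest neighbour, compound 2 `Cc1cccc(NC(=O)Nc2cccc(CNc3ncnc4ccccc34)c2)c1`, gives 30200 nM in this assay, and the gap between them is within the scatter a 1.1-fold lower number from compound 2 to compound 3 (0.04 log units; within the scatter). Compound 1 `Cc1ccccc1NC(=O)Nc1cccc(CNc2ncnc3ccccc23)c1` reaches only a limit of the assay, not a number, in this assay: > 50000 nM (the limit of > 50000 nM in this assay, at which 1 of the 3 values shown sits). The steps of an at least 1.6-fold lower number from compound 1 to compound 2 (0.21 log units; that floor lies within the scatter) and an at least 1.8-fold lower number from compound 1 to compound 3 (0.26 log units; that floor lies within the scatter) both start from that limit and stay within the scatter.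

Compound 4 `CC(C)(C)c1ccc(NC(=O)Nc2cccc(CNc3ncnc4ccccc34)c2)cc1` differs from compound 3 in a single place: tert-butyl in place of methoxy on an aromatic carbon. Within the data shown here, none of the measured steps exchanges these two groups, and every measured step sits within the scatter, so no shift beyond the scatter is expected, a 1.1-fold lower number from compound 3 to compound 4 (0.04 log units; within the scatter). Compound 4 is therefore estimated at 25000 nM, within a range from 8000 nM to 60000 nM.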

Compound 4, half-maximal inhibitory concentration: 7470 nM
Estimate against measurement, compound 4: 3.3-fold (0.52 log units) above; the whole stated range lies above it.
By their numbers in this assay, from the lowest: compound 4; then compounds 3 and 2 (each within the scatter of the next). At a limit, above all of these: compound 1.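

In this assay, earlier changes on this ring stayed within the scatter, but tert-butyl in place of methoxy, para to a large group, goes beyond it, with a 3.7-fold lower number from compound 3 to compound 4 (0.56 log units; beyond the scatter). The 4-(tert-butyl)phenyl compound also stands apart from the 3-methylphenyl compound, with a 4.0-fold lower number from compound 2 to compound 4 (0.61 log units; beyond the scatter), and from the 2-methylphenyl compound, with an at least 6.6-fold lower number from compound 1 to compound 4 (0.82 log units; beyond the scatter). That last step starts from a limit, not a number, reached by compound 1: the limit of > 50000 nM in this assay, at which 1 of the 4 values shown sits.

As far as these compounds go, it remains open whether an isopropyl group, an amine or a carboxylic acid at this place would give a similar number. Also open, from the compounds shown here alone, is whether tert-butyl elsewhere on the ring would do the same.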